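Monomer Chain Variation Beside the Dimeric References

The source may report more compounds than this note shows. Statements on the series, on what has been measured and on what is new or still open speak of the compounds shown alone.

Compounds 1 and 2 are linked dimers of the shared core: compound 1 `O=C(Nc1ccc2[nH]cc(C3CCN(CCCCCCN4CCC(c5c[nH]c6ccc(NC(=O)c7ccc(F)cc7)cc56)CC4)CC3)c2c1)c1ccc(F)cc1` and compound 2 `O=C(Nc1ccc2[nH]cc(C3CCN(CCCCCCCCCCCCN4CCC(c5c[nH]c6ccc(NC(=O)c7ccc(F)cc7)cc56)CC4)CC3)c2c1)c1ccc(F)cc1`. In an assay on CHO-K1 cells for displacement of a labelled ligand from 5-hydroxytryptamine receptor 1D (Homo sapiens), read by scintillation counting (a higher number here means a weaker inhibitor, a lower number a stronger inhibitor), compound 1 gives 0.6 nM and compound 2 gives 13 nM. Compound 3 `CCCCCCCCN1CCC(c2c[nH]c3ccc(NC(=O)c4ccc(F)cc4)cc23)CC1` keeps a single core with one saturated chain on the ring amine. In this assay compound 3 is reported only as a limit, > 1000 nM. Going by the values given here, that is the situation described by the limit of > 1000 nM in this assay, at which 1 of the 3 values shown sits, so where compound 3 truly stands is not known and no numerical step can be drawn from it.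

Compound 4 `CN(C)CCCN1CCC(c2c[nH]c3ccc(NC(=O)c4ccc(F)cc4)cc23)CC1` is the next monomer. The change from compound 3 is dimethylamino in place of pentyl on a saturated chain carbon, three bonds along the chain from an amine nitrogen in a ring. No measured pair in this set differs in one place, so nothing shown fixes the size of this step in this assay. Among the compounds with values here, with only one core retained, the expected step is an at least 1.2-fold lower number from compound 3 to compound 4 (0.09 log units; that floor lies within the scatter), read against a limit rather than a number, and a weak result is still expected. For compound 4 the estimate in this assay is 800 nM, in the range 150 nM to 4000 nM.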

Compound 4, inhibition constant: > 1000 nM
Compound 4: only a limit was reported (the forecaster's own chance of this, stated with the estimate: 45%); middle value at least 1.2-fold (0.09 log units) away from the limit.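

Compound 3 and compound 4 are both reported only as limits in this assay, so no step between them can be read: the limit of > 1000 nM in this assay, at which 2 of the 4 values shown sit.

The compounds shown leave open where either monomer truly stands, and whether 3-(dimethylamino)propyl and octyl differ at all on the shared core.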